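The source may report more compounds than this note shows. Statements on the series, on what has been measured and on what is new or still open speak of the compounds shown alone.

Measured compounds:
- Compound 1 `CC1=CC[C@@H]([C@@](C)(O)CCCC(C)(C)NC(=S)N/N=C\c2ccccc2)CC1`: 12900 nM
- Compound 2 `COc1ccc(/C=N\NC(=S)NC(C)(C)CCC[C@](C)(O)[C@@H]2CC=C(C)CC2)cc1`: 15800 nM
- Compound 3 `CC1=CC[C@@H]([C@@](C)(O)CCCC(C)(C)NC(=S)N/N=C\c2ccccc2[N+](=O)[O-])CC1`: 16200 nM

In a functional assay on OVCAR-3 cells (Homo sapiens) for cytotoxicity, read by sulforhodamine B assay (on this read-out higher numbers stand for weaker inhibition of growth and lower numbers for stronger inhibition of growth), compound 1 cannot be told apart from compound 2 or compound 3, since all three values lie within the usual scatter of each other. The next compound, compound 4 `CC1=CC[C@@H]([C@@](C)(O)CCCC(C)(C)NC(=S)N/N=C\c2cccc([N+](=O)[O-])c2)CC1`, differs from compound 1 by one change: nitro in place of hydrogen on an aromatic carbon. Phenyl becomes 3-nitrophenyl, with the nitro meta to a large group.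

The closest guide is the step to compound 3, which also gains a nitro, there as 2-nitrophenyl: a 1.3-fold higher number from compound 1 to compound 3 (0.10 log units; within the scatter). Placing a methoxy on the same ring gave a similarly small result: a 1.2-fold higher number from compound 1 to compound 2 (0.09 log units; within the scatter). Swapping one substituted ring for the other also changed little: a 1.0-fold higher number from compound 2 to compound 3 (0.01 log units; within the scatter). For the measured compounds named here, no measured compound carries the 3-nitrophenyl group, so this rests on few data, but no shift beyond the scatter is expected in this assay. The expected step is a 1.1-fold higher number from compound 1 to compound 4 (0.05 log units; within the scatter). For compound 4 the estimated value is 14500 nM, with an expected range of 9000 nM to 23000 nM.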

Compound 4, concentration for total growth inhibition: 40800 nM
For compound 4 the middle estimate is 2.8-fold (0.45 log units) below the measured one, and the stated range ends below it.
By their numbers in this assay, from the lowest: compounds 1, 2 and 3 (each within the scatter of the next); then compound 4.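

In this assay, adding a nitro group to the ring of compound 1 can shift the result beyond the scatter, as 3-nitrophenyl gives a 3.2-fold higher number from compound 1 to compound 4 (0.50 log units; beyond the scatter) and makes compound 4 the weakest growth inhibitor of the four. Position on the ring now matters, since moving from 2-nitrophenyl to 3-nitrophenyl gives a 2.5-fold higher number from compound 3 to compound 4 (0.40 log units; beyond the scatter) even though the nitro group itself stays the same. Compound 4 also separates from the methoxy-bearing compound, with a 2.6-fold higher number from compound 2 to compound 4 (0.41 log units; beyond the scatter), so the earlier flat picture does not hold for every substituent on this ring.

Nothing available explains why this placement gives a higher number. As far as these compounds go, it also remains open whether an amine or a nitrile, meta to a large group, would give a similar shift.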